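Working notes on a small 5-HT1D agonist series

This account rests on a few compounds, and the source may have more. Where it says the series, first, only, none or still open, it means among the compounds named here.

compound 1, `OCCC(NC1CCN(CCCc2c[nH]c3ccc(-n4cnnc4)cc23)CC1)c1ccccc1`: 100%
compound 2, `COC[C@H](NC1CCN(CCCc2c[nH]c3ccc(Cn4cncn4)cc23)CC1)c1ccc(F)cc1`: 89%

In a functional assay on CHO cells for activation of 5-hydroxytryptamine receptor 1D (Homo sapiens), read by GTPgammaS binding (a higher number here means a larger maximal response, a lower number a smaller maximal response), compound 1 gives 100%, the higher of the two numbers; compound 2 gives 89%, a gap beyond the usual scatter. Compound 3, `c1ccc(CNCC2CCN(CCCc3c[nH]c4ccc(-n5cnnc5)cc34)CC2)cc1`, is not yet measured. It differs from compound 1 in one place: (benzylamino)methyl in place of (3-hydroxy-1-phenylpropyl)amino on a saturated ring carbon. Going by the values given here, no measured pair with a single change is available, so the step is judged from compound 1 and compound 2 alone. Both give a near-full maximal response, so only a small step is expected in this assay, leaning slightly downward. Compound 3 is expected to give 94%, between 78% and 106%. The expected step is a number 6 percentage points lower from compound 1 to compound 3 (within the scatter).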

Compound 3, largest response reached (reported as efficacy), in percent of the reference or control that the assay uses: 101%
The estimate for compound 3 lay 7 percentage points below the measured number; low and high end bracket the measured number.
By their numbers in this assay, from the lowest: compound 2; then compounds 1 and 3 (each within the scatter of the next).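

In this assay, (benzylamino)methyl in place of (3-hydroxy-1-phenylpropyl)amino on the saturated ring carbon gives a number 1 percentage points higher from compound 1 to compound 3 (within the scatter) at this position. The maximal response therefore holds with the smaller group, which carries no oxygen. No measurement on hand accounts for this result.

As far as these compounds go, whether a carboxylic acid or a longer chain on this ring carbon would hold the response stays open. So does whether an amide in place of the amine nitrogen of (benzylamino)methyl would do so.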